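Pyridin-3-yl in place of 4-chlorophenyl: working notes

A few compounds are considered here, and "the series" means these few. Any claim that something is new, unique, unknown or untested is made for them only; others in the source may bear on it.

- compound 1 `CC(=O)N1N=C(c2ccc3ccccc3c2)OC1c1ccc(Cl)cc1` gives 1.88 ug/mL
- compound 2 `CC(=O)N1N=C(c2ccc3ccccc3c2)OC1c1cccc(F)c1` gives 1.86 ug/mL
- compound 3 `CC(=O)N1N=C(c2ccc3ccccc3c2)OC1c1ccc2ccccc2c1` gives 0.85 ug/mL

In a functional assay on HepG2 cells (Homo sapiens) for antiproliferative activity, read by MTT assay, with a stated time of 48 h (on this read-out lower numbers stand for stronger inhibition and higher numbers for weaker inhibition), compound 1 (1.88 ug/mL) and compound 2 (1.86 ug/mL) sit level within the scatter, while compound 3 (0.85 ug/mL) gives a lower number than either. The next comparison is with compound 4 `CC(=O)N1N=C(c2ccc3ccccc3c2)OC1c1cccnc1` and the change is pyridin-3-yl in place of 4-chlorophenyl on a saturated ring carbon with pyridin-3-yl in place of 4-chlorophenyl on a saturated ring carbon. For the measured compounds named here, the one measured step at that carbon is a 1.0-fold lower number from compound 1 to compound 2 (0.00 log units; within the scatter) with 3-fluorophenyl entering. Compound 3 (0.85 ug/mL) shows that the number can still move when the group at that carbon differs. Going by the values given here, no measured compound carries a ring with a hetero atom there, so the range stays wide. No step beyond the scatter is therefore expected in this assay and any drift is expected toward a higher number. The estimated step is a 1.2-fold higher number from compound 1 to compound 4 (0.07 log units; within the scatter) as the working figure. For compound 4 the estimated value is 2.2 ug/mL with 0.9 ug/mL to 6 ug/mL as the expected range.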

Compound 4, half-maximal inhibitory concentration: 2.86 ug/mL
Compound 4: middle estimate off by 1.3-fold (0.11 log units), on the low side, within the range that was stated.
By their numbers in this assay, from the lowest: compound 3; then compounds 2, 1 and 4 (each within the scatter of the next).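

In this assay, for the compounds shown here, pyridin-3-yl is the first ring with a hetero atom at this saturated ring carbon, and the steps are a 1.5-fold higher number from compound 1 to compound 4 (0.18 log units; within the scatter) and a 1.5-fold higher number from compound 2 to compound 4 (0.19 log units; within the scatter). A hydrogen-bond acceptor can therefore enter on this ring, with the halogen gone, without a step beyond the scatter from either halogenated phenyl compound, while compound 3 still holds the lowest number at 0.85 ug/mL. Nothing measured here bears on why these numbers sit level.

Still open, from the compounds shown here alone, is whether a ring carrying an amine, such as piperidin-4-yl, or a phenyl ring carrying a carboxylic acid would move the number beyond the scatter at this carbon. Also open, going by these compounds, is whether pyridin-2-yl or pyridin-4-yl would read the same as pyridin-3-yl.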